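The source may hold more compounds than are shown below. What is called first, only, known or untested is meant among the compounds shown, and "the series" means these compounds.

Three analogues of the shared core have numbers in a functional assay on BJAB cells (Homo sapiens) for antiproliferative activity, with a stated time of 4 days; on this read-out lower numbers stand for an effect already at smaller amounts and higher numbers for an effect only at larger amounts of compound. Compound 1 `Cc1c(-c2cc(Cl)cc(Cl)c2)c(C(=O)O)nn1-c1nc(-c2cc(Cl)ccc2F)c(SC(C)C)s1` gives 4800 nM in this assay; compound 2 `Cc1nn(-c2nc(-c3ccc(Cl)c(Cl)c3)c(SC(C)C)s2)c(C(=O)O)c1-c1cnn(C)c1` gives 6800 nM; compound 3 `CCSc1sc(-n2nc(C)c(Cc3ccccc3[N+](=O)[O-])c2C(=O)OC)nc1-c1ccc(Cl)c(Cl)c1` gives 106000 nM. Compound 2 stands second highest of the three: its gap to compound 1 lies within the scatter, while compound 3 sits far higher, beyond the scatter. Compound 4 `Cc1nn(-c2nc(-c3ccc(Cl)c(Cl)c3)c(SC(C)C)s2)c(C(=O)O)c1-c1ccccc1Cl` is the next member and is not yet measured. Against compound 2 the change is 2-chlorophenyl in place of 1-methyl-1H-pyrazol-4-yl on an aromatic carbon. Going by the values given here, no measured pair in the set isolates this change, so only a small step, if any, is expected in this assay, tending toward the lower numbers seen for compound 1. The step is expected to be a 1.7-fold lower number from compound 2 to compound 4 (0.23 log units; within the scatter). For compound 4 the estimate in this assay is 4000 nM, with a range from 1500 nM to 12000 nM.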

Compound 4, half-maximal effective concentration: 13100 nM
Beside the measured number, compound 4's estimate is 3.3-fold (0.52 log units) below it; measured number above the stated range.
By their numbers in this assay, from the lowest: compounds 1, 2 and 4 (each within the scatter of the next, the first and the last beyond it); then compound 3.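

In this assay, going by these compounds alone, the first direct pair at this position, on an aromatic carbon next to the ring atom that bears a carboxy group, gives a 1.9-fold higher number from compound 2 to compound 4 (0.28 log units; within the scatter) for 2-chlorophenyl in place of 1-methyl-1H-pyrazol-4-yl. The two groups are therefore not told apart here, although a ring with 2 hetero atoms and 2 hydrogen-bond acceptors gives way to a ring of carbon only with none. Nothing available explains this result.

Going by these compounds, whether an amine or a longer chain on this carbon would give a step beyond the scatter stays open. So does whether this result would hold with a different group in place of the carboxy group.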